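A Carboxy Group Replaces Trifluoromethyl on a Shared Core

This account rests on a few compounds, and the source may have more. Where it says the series, first, only, none or still open, it means among the compounds named here.

Measured so far:
Compound 1, `O=c1cc(-c2ccccc2)oc2cc(OCCCCNc3nc4ccc([N+](=O)[O-])cc4s3)cc(O)c12`, gives 30.3 ug/mL
Compound 2, `O=c1cc(-c2ccccc2)oc2cc(OCCCCNc3nc4ccc(C(F)(F)F)cc4s3)cc(O)c12`, gives 16.3 ug/mL

Both numbers come from a physicochemical assay, read by spectrophotometry, with a stated time of 25 min; a lower number here means a stronger inhibitor, a higher number a weaker inhibitor. Going by the values given here, the only step between measured compounds, a 1.9-fold lower number from compound 1 to compound 2 (0.27 log units; within the scatter), lies within the scatter, so although compound 2 has the lower of the two numbers, it cannot be called the stronger inhibitor. Compound 3, `O=C(O)c1ccc2nc(NCCCCOc3cc(O)c4c(=O)cc(-c5ccccc5)oc4c3)sc2c1`, carries the change (carboxy in place of trifluoromethyl on an aromatic carbon). Among the compounds with values here, no measured step involves a carboxy group, so the change is not directly covered. Within the data shown here, the one step available shows that swapping a group at this same position, nitro for trifluoromethyl, left the number within the scatter, and on that basis a step of about the same small size is expected here, a 1.3-fold higher number from compound 2 to compound 3 (0.13 log units; within the scatter). For compound 3 the estimate in this assay is 22 ug/mL, with a range from 9 ug/mL to 55 ug/mL.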

Compound 3, half-maximal inhibitory concentration: 21.7 ug/mL
For compound 3 the middle estimate is 1.0-fold (0.01 log units) above the measured one; low and high end bracket the measured number.
By their numbers in this assay, from the lowest: compounds 2, 3 and 1 (each within the scatter of the next).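

In this assay the carboxy group brings a hydrogen-bond donor and a hydrogen-bond acceptor that trifluoromethyl does not have, yet the exchange gives a 1.3-fold higher number from compound 2 to compound 3 (0.12 log units; within the scatter) and stays small. Set against nitro, the same group gives a 1.4-fold lower number from compound 1 to compound 3 (0.14 log units; within the scatter) and again stays within the scatter. Three different groups at this position on the shared core therefore give numbers that cannot be told apart, something a single pair could not show, and no measurement at hand explains this result.

Going by these compounds, whether an amine, a hydroxy group or a plain hydrogen at this position would also fall within the scatter remains open. Going by these compounds alone, also open is whether a longer chain than the one these compounds share would give a number clearly different from theirs.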